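This account rests on a few compounds, and the source may have more. Where it says the series, first, only, none or still open, it means among the compounds named here.

Compound 3 `OC[C@H]1C[C@@H](Cn2cnc3c(-c4ccccc4)ncnc32)c2ccccc21` and compound 1 `COc1ccc(-c2ncnc3c2ncn3C[C@@H]2C[C@H](CO)c3ccccc32)cc1` share a core and differ in one place (methoxy in place of hydrogen on an aromatic carbon). In an ADME assay on L1210/0 cells (Mus musculus) for cytotoxicity, with a stated time of 48 h (a lower number here means a stronger inhibitor, a higher number a weaker inhibitor), compound 3 gives 28100 nM, and compound 1 gives 17600 nM; the step of a 1.6-fold lower number from compound 3 to compound 1 (0.20 log units; within the scatter) is small. Compound 2 `O[C@H]1C[C@@H](Cn2cnc3c(-c4ccccc4)ncnc32)c2ccccc21` carries the same core, with the difference (hydroxy in place of hydroxymethyl on a saturated ring carbon). In this assay compound 2 reaches only a limit, > 200000 nM, which is the limit (the limit of > 200000 nM in this assay, at which 1 of the 3 values shown sits). The step of an at least 7.1-fold lower number from compound 2 to compound 3 (0.85 log units; beyond the scatter) is therefore a lower bound. Compound 4 `COc1ccccc1-c1ncnc2c1ncn2C[C@@H]1C[C@H](O)c2ccccc21` is not yet measured; it stands to compound 2 as compound 1 stands to compound 3, through (methoxy in place of hydrogen on an aromatic carbon). This is the same kind of change, but not the same: in the measured pair the methoxy sits para to a large group, in the new pair ortho to a large group. Since the measured step of a 1.6-fold lower number from compound 3 to compound 1 (0.20 log units; within the scatter) lies within the scatter, compound 4 is expected to move little, a number no higher from compound 2 to compound 4 (the limit leaves the size open), and most likely to remain at the limit. Compound 4 is estimated at 200000 nM, between 90000 nM and 500000 nM.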

Compound 4, half-maximal inhibitory concentration: > 200000 nM
Compound 4 gave a limit, no number (the forecaster's own chance of this, stated with the estimate: 70%); the middle value lies on the limit itself.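

Compound 2 and compound 4 each reach only a limit in this assay, so no step between them can be read: the limit of > 200000 nM in this assay, at which 2 of the 4 values shown sit.

The compounds shown leave open what number either compound would give, and whether 2-methoxyphenyl in place of phenyl changes the result on this core at all.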